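This account rests on a few compounds, and the source may have more. Where it says the series, first, only, none or still open, it means among the compounds named here.

Measured so far:
compound 1 `COc1c(NS(=O)(=O)c2ccc(F)cc2)cc(-c2ccc3nc(NC(C)=O)nn3c2)cc1C(N)=O`, 25400 nM
compound 2 `COc1c(NS(=O)(=O)c2ccc(F)cc2)cc(-c2ccc3nc(NC(=O)C4CC4)sc3c2)cc1C(N)=O`, 2010 nM
compound 3 `NC(=O)c1cc(-c2ccc3nc(NC(=O)C4CC4)sc3c2)cc(NS(=O)(=O)c2ccc(F)cc2)c1Cl`, 11400 nM

In a functional assay on HCT-116 cells (Homo sapiens) for antiproliferative activity, read by MTT assay, with a stated time of 72 h (a lower number here means a stronger inhibitor, a higher number a weaker inhibitor), compound 3 stands second highest of the three numbers: compound 2 sits at the lower end, and compound 1 sits higher still. Compound 4 `NC(=O)c1cc(NS(=O)(=O)c2ccc(F)cc2)cc(-c2ccc3nc(NC(=O)C4CC4)sc3c2)c1` is compound 3 with the change (hydrogen in place of chloro on an aromatic carbon).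

Among the measured compounds shown here, the one measured step that bears on this position is a 5.7-fold higher number from compound 2 to compound 3 (0.75 log units; beyond the scatter), a change at the same aromatic carbon. Its size shows that what sits at this carbon moves the number beyond the scatter. Removal of the chloro has no direct precedent; hydrogen is neither of the two groups compared. The step of a 1.6-fold lower number from compound 3 to compound 4 (0.21 log units; within the scatter) is therefore expected to be modest and toward a lower number, with wide uncertainty. Compound 4 is estimated at 7000 nM, with a range from 2000 nM to 25000 nM.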

Compound 4, half-maximal inhibitory concentration: > 50000 nM
Compound 4 ended at the assay's limit; the forecaster's own chance of this, stated with the estimate: 10%; at least 7.1-fold (0.85 log units) between middle value and limit.
By their numbers in this assay, from the lowest: compound 2; then compound 3; then compound 1. At a limit, above all of these: compound 4.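

Compound 4 stands at a limit of the assay, not at a number: the limit of > 50000 nM in this assay, at which 1 of the 4 values shown sits.

Even so, the loss on removing the chloro is readable, with an at least 4.3-fold higher number from compound 3 to compound 4 (0.64 log units; beyond the scatter), and removing the methoxy gives an at least 24-fold higher number from compound 2 to compound 4 (1.39 log units; beyond the scatter). Among the compounds shown here, the earlier compounds ranked only two groups at this aromatic carbon; hydrogen now joins them and gives the highest reading of the three, so methoxy, chloro and hydrogen fall in that order.

From the compounds shown here alone, whether a hydroxyl, an amine, a methyl or an ethoxy at this carbon would match the methoxy stays open. So does whether the same order holds on the core of compound 1.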